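The source may report more compounds than this note shows. Statements on the series, on what has been measured and on what is new or still open speak of the compounds shown alone.

Compound 1 (`N#Cc1cc(C(=O)N2CS(=O)(=O)c3ccccc32)cc(Cl)c1O`): 3870 nM
Compound 2 (`CC(C)c1cc(C(=O)N2CS(=O)(=O)c3ccccc32)cc(C#N)c1O`): 12500 nM
Compound 3 (`CSc1cc(C(=O)N2CS(=O)(=O)c3ccccc32)cc(C#N)c1O`): 3000 nM

These three compounds were compared in an ADME assay on the whole organism (Rattus norvegicus) for pharmacokinetics, read by HPLC, at a dose of 3 mg/kg by the oral route; on this read-out lower numbers stand for lower exposure and higher numbers for higher exposure at the dose given. Compound 3, at 3000 nM, cannot be told apart from compound 1, as the record shows a 1.3-fold lower number from compound 1 to compound 3 (0.11 log units; within the scatter). Compound 2 stands clear of it, with a 4.2-fold lower number from compound 2 to compound 3 (0.62 log units; beyond the scatter).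

The next compound, compound 4 (`CSc1cc(C(=O)N2CS(=O)(=O)c3ccccc32)cc(Cl)c1O`), keeps the methylsulfanyl group of compound 3 and has chloro in place of cyano on an aromatic carbon, ortho to a hydroxy group (chloro in place of cyano on an aromatic carbon). For the measured compounds named here, no measured pair makes this exchange directly, so the evidence is indirect. The other substituent position has been varied only with cyano held in place. There, the exchange of chloro for methylsulfanyl gave a 1.3-fold lower number from compound 1 to compound 3 (0.11 log units; within the scatter), while the exchange of chloro for isopropyl gave a 3.2-fold higher number from compound 1 to compound 2 (0.51 log units; beyond the scatter). Single exchanges in this small set can therefore stay within the scatter or go modestly beyond it, and neither direction is established for the cyano position. In this assay, no step beyond the scatter is expected, though the uncertainty is wide. The expected step is a 1.2-fold higher number from compound 3 to compound 4 (0.07 log units; within the scatter). The estimate for compound 4 is 3500 nM, with an expected range from 1300 nM to 10000 nM.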

Compound 4, maximal plasma concentration: 12500 nM
For compound 4 the middle estimate is 3.6-fold (0.55 log units) below the measured one; measured number above the stated range.
By their numbers in this assay, from the lowest: compounds 3 and 1 (each within the scatter of the next); then compounds 2 and 4 (each within the scatter of the next).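

With methylsulfanyl held in place, chloro in place of cyano gave a 4.2-fold higher number from compound 3 to compound 4 (0.62 log units; beyond the scatter) in this assay, so this exchange, ortho to a hydroxy group, moves the number beyond the scatter. With chloro held in place, methylsulfanyl in place of cyano gave a 3.2-fold higher number from compound 1 to compound 4 (0.51 log units; beyond the scatter), while methylsulfanyl in place of chloro with cyano held in place gave only a 1.3-fold lower number from compound 1 to compound 3 (0.11 log units; within the scatter), so the outcome of a single exchange here depends on which group remains. Both new steps remove cyano and raise the number, but compound 2 goes against any simple reading, since it keeps cyano and still gives 12500 nM. Nothing shown here accounts for these differences.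

The compounds shown leave open whether chloro in place of cyano would also raise the number with isopropyl held in place. They also leave open how an amine, a carboxylic acid or a longer chain at this place would compare with chloro and cyano.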